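The source may hold more compounds than are shown below. What is called first, only, known or untested is meant among the compounds shown, and "the series" means these compounds.

Series notes. Compound 1 `COC1Cc2cc(-c3ccccc3)sc2C2(CCN(Cc3ccccc3)CC2)O1` and compound 2 `COC1Cc2cc(-c3ccc([N+](=O)[O-])cc3)sc2C2(CCN(Cc3ccccc3)CC2)O1` set the reference level: in an assay on membranes from brain for displacement of a labelled ligand from Sigma non-opioid intracellular receptor 1 (Cavia porcellus), read by scintillation counting, with a stated time of 120 min (on this read-out higher numbers stand for weaker inhibition and lower numbers for stronger inhibition), compound 1 gives 16 nM and compound 2 gives 16 nM, the two numbers lying within the scatter of each other, as no change at the digits printed from compound 1 to compound 2 (within the scatter) shows. Compound 3 `COC1Cc2cc(-c3ccc(C(C)=O)cc3)sc2C2(CCN(Cc3ccccc3)CC2)O1` gives 59 nM and stands with the highest number of the three measured compounds; the steps of a 3.7-fold higher number from compound 1 to compound 3 (0.57 log units; beyond the scatter) and a 3.7-fold higher number from compound 2 to compound 3 (0.57 log units; beyond the scatter) both run upward past the scatter, by a modest margin each. Compound 4 `COC1Cc2cc(-c3ccc(C#N)cc3)sc2C2(CCN(Cc3ccccc3)CC2)O1` has not been measured. The change from compound 3 to compound 4 is cyano in place of acetyl on an aromatic carbon. The measured steps that bear on it are the arrival of acetyl on this aromatic carbon, whether in place of hydrogen or of nitro, which raised the number each time, a 3.7-fold higher number from compound 1 to compound 3 (0.57 log units; beyond the scatter) and a 3.7-fold higher number from compound 2 to compound 3 (0.57 log units; beyond the scatter) being the evidence. Taking acetyl away again for cyano, a group of two heavy atoms, is therefore expected to undo most of that rise, and since compound 2 with nitro sat at 16 nM, compound 4 is expected near that level and not beyond it. The expected step is a 2.7-fold lower number from compound 3 to compound 4 (0.43 log units; beyond the scatter), downward. The estimate for compound 4 in this assay is 22 nM, with a range from 9 nM to 55 nM.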

Compound 4, inhibition constant: 20 nM
Estimate against measurement, compound 4: 1.1-fold (0.04 log units) above; the measured number falls inside the stated range.
By their numbers in this assay, from the lowest: compounds 1, 2 and 4 (each within the scatter of the next); then compound 3.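

Notes on the position. In this assay, the change from 4-acetylphenyl to 4-cyanophenyl gives a 3.0-fold lower number from compound 3 to compound 4 (0.47 log units; beyond the scatter) and so shows that a second group on this aromatic carbon, one that also brings a multiple bond outside the aromatic rings and a hydrogen-bond acceptor, does not share the rise seen with acetyl. Cyano also stays level with the other two groups, with a 1.3-fold higher number from compound 2 to compound 4 (0.10 log units; within the scatter) and a 1.3-fold higher number from compound 1 to compound 4 (0.10 log units; within the scatter), so compounds 1, 2 and 4 form a single level and compound 3 is the only compound that goes against it. No measurement is available that would explain why acetyl separates from cyano, nitro and hydrogen at this position.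

From the compounds shown here alone, it remains open whether the rise belongs to the carbonyl or to the methyl of acetyl, which a formyl group, a primary amide or a carboxylic acid on the same aromatic carbon would help to separate. Going by these compounds, it is also open whether any group here, such as an amine or a longer acyl chain, moves the number away from this level in either direction.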